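This account rests on a few compounds, and the source may have more. Where it says the series, first, only, none or still open, it means among the compounds named here.

Compound 3 `NS(=O)(=O)Oc1ccc2c(c1)CN(C(=O)c1cccc(N3CCCCC3)c1)CC2` gives 1% in an assay on HEK293 cells for inhibition of Steryl-sulfatase (Homo sapiens), tested at 0.1 uM (a lower number here means a weaker effect, a higher number a stronger effect of the compound at the concentration tested), the second highest of the three numbers on hand. Compound 1 `NS(=O)(=O)Oc1ccc2c(c1)CN(C(=O)c1cccc(N3CCC(N4CCCCC4)CC3)c1)CC2` gives 0%, and the step of a number 1 percentage points higher from compound 1 to compound 3 (within the scatter) lies within the scatter. Compound 2 `CCN(Cc1ccccc1)c1ccc(C(=O)N2CCc3ccc(OS(N)(=O)=O)cc3C2)cc1` gives 66.9%, a number far beyond the scatter from compound 3. Compound 4 `CCN(Cc1cccnc1)c1cccc(C(=O)N2CCc3ccc(OS(N)(=O)=O)cc3C2)c1` carries ethyl((pyridin-3-yl)methyl)amino in place of piperidin-1-yl on an aromatic carbon. Among the measured compounds shown here, no measured step covers this exchange; the one step available concerns a different place and is within the scatter. For the measured compounds named here, compound 2, which carries a related open-chain amino group, is the only compound with a clear read-out, so a rise is expected. The step of a number 39 percentage points higher from compound 3 to compound 4 (beyond the scatter) is expected to reach beyond the scatter. Compound 4 is estimated at 40%, within 10% to 70%.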

Compound 4, a percentage reported as inhibition, at one concentration (the size of the read-out at that concentration, not a potency): 14.3%
Compound 4: middle estimate off by 25.7 percentage points, on the high side; the range from low to high includes it.
By their numbers in this assay, from the lowest: compounds 1 and 3 (each within the scatter of the next); then compound 4; then compound 2.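

In this assay, ethyl((pyridin-3-yl)methyl)amino in place of piperidin-1-yl on this aromatic carbon, meta to a large group, gives a number 13.3 percentage points higher from compound 3 to compound 4 (beyond the scatter). The read-out therefore responds to the group at this position, whereas the earlier step, on a saturated ring carbon, stayed within the scatter. Nothing on hand accounts for the gain.

Going by these compounds, it remains open whether the ethyl, the pyridin-3-yl ring or the loss of the piperidine ring carries the step. A dimethylamino or morpholin-4-yl group on this carbon would help separate these.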